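Moving the methoxy group: from compound 1 to compound 4

The source may hold more compounds than are shown below. What is called first, only, known or untested is meant among the compounds shown, and "the series" means these compounds.

Compound 1 `COc1ccc(S(=O)(=O)Nc2ccc(-c3nc4ccccc4o3)cc2)cc1` carries a 4-methoxyphenyl on the sulfonyl sulfur. In an ADME assay on HEK293 cells (Homo sapiens) for cytotoxicity, read by resazurin assay, with a stated time of 48 h (a higher number here means that more compound is tolerated, a lower number that less compound is tolerated), compound 1 gives > 100000 nM, which is a limit of the assay and not a number. Compound 1 therefore sits at the limit of > 100000 nM in this assay, at which 1 of the 3 values shown sits, so its true value is not pinned down. Compound 3 `O=S(=O)(Nc1ccc(-c2nc3ccccc3o2)cc1)c1ccc(C(F)(F)F)cc1` gives 94000 nM in this assay, and the step of an at least 1.0-fold lower number from compound 1 to compound 3 (0.02 log units; that floor lies within the scatter) concerns a different group and lies within the scatter. Compound 2 `O=S(=O)(Nc1ccc2oc(-c3ccccc3)nc2c1)c1ccc(Cl)c(C(F)(F)F)c1`, with the sulfonamide placed differently on the shared core, gives 66000 nM in this assay.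

Compound 4 `COc1cccc(S(=O)(=O)Nc2ccc(-c3nc4ccccc4o3)cc2)c1` has not yet been measured. Its change from compound 1 is 3-methoxyphenyl in place of 4-methoxyphenyl on a sulfonyl sulfur. Among the measured compounds shown here, no measured step in the set bears on this change, and the one measured step, an at least 1.0-fold lower number from compound 1 to compound 3 (0.02 log units; that floor lies within the scatter), is itself within the scatter. On that basis the expected step of a number no higher from compound 1 to compound 4 (the limit leaves the size open) is none beyond the scatter, with the caveat that compound 1 itself is only a limit. Compound 4 is estimated at 100000 nM in this assay, within a range from 50000 nM to 200000 nM.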

Compound 4, half-maximal cytotoxic concentration: > 100000 nM
Compound 4 gave a limit, no number (the forecaster's own chance of this, stated with the estimate: 50%); the middle value sits exactly at the limit.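

In this assay compound 4 gives > 100000 nM, which is a limit of the assay and not a number; compound 1 is also only a limit, so no step can be read between compound 1 and compound 4. The compounds shown leave open whether 3-methoxyphenyl in place of 4-methoxyphenyl on a sulfonyl sulfur changes the tolerated concentration at all.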